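This account rests on a few compounds, and the source may have more. Where it says the series, first, only, none or still open, it means among the compounds named here.

Three compounds sharing one core have been run in an ADME assay on liver (Mus musculus, strain CD1) for metabolic stability, read by HPLC, using microsomes and NADPH, with a stated time of 45 min, tested at 1 uM (a higher number here means faster removal of the compound, a lower number slower removal), so far. In that assay compound 1 `O=C(CCc1nc2cccnc2n1Cc1ccccc1)NCC1CCCCC1` gives 30.8 mL/min and compound 2 `C[C@H](NC(=O)CCc1nc2cccnc2n1Cc1ccccc1)c1ccccc1` gives 21.4 mL/min in the same assay, while compound 3 `C[C@H](NC(=O)CCc1nc2cccnc2n1Cc1ccc(C(F)(F)F)cc1)c1ccc(Cl)cc1` gives 26.5 mL/min there. Within the data shown here, the only pair that differs in a single place is the one where a 1.4-fold lower number from compound 1 to compound 2 (0.16 log units; within the scatter) was seen, a change on the amide-type nitrogen that stays within the scatter. Compound 3 stands second highest of the three numbers, nearest to compound 1 and furthest from compound 2, and both of those gaps lie within the scatter.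

Compound 4 `C[C@H](NC(=O)CCc1nc2cccnc2n1Cc1ccc(OC(F)F)cc1)c1ccc(Cl)cc1` differs from compound 3 in one place, namely difluoromethoxy in place of trifluoromethyl on an aromatic carbon on the benzyl group. Cut one bond further out, the change reads 4-(trifluoromethyl)benzyl to 4-(difluoromethoxy)benzyl. Among the measured compounds shown here, no measured step touches this position or either of these groups, and no measured compound carries difluoromethoxy, so nothing here points to a step beyond the scatter in either direction. The step that the estimate implies, a 1.0-fold higher number from compound 3 to compound 4 (0.01 log units; within the scatter), is expected to be small. Compound 4 is therefore estimated at 27 mL/min with a range from 14 mL/min to 54 mL/min in that assay.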

Compound 4, intrinsic clearance in a liver preparation (reported as CLH), per the amount of preparation that the assay uses: 52.8 mL/min
The estimate for compound 4 lay 2.0-fold (0.29 log units) below the measured number, and the stated range covers the measured number.
By their numbers in this assay, from the lowest: compounds 2, 3, 1 and 4 (each within the scatter of the next, the first and the last beyond it).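

The benzyl group now has its first measured step: replacing trifluoromethyl with difluoromethoxy on the aromatic carbon para to a large group gives a 2.0-fold higher number from compound 3 to compound 4 (0.30 log units; within the scatter) in this assay. Among these compounds, this step stays within the scatter, so the exchange, which keeps the same number of heavy atoms and brings in an oxygen, cannot be told apart from no change in this assay, although the earlier compounds had said nothing about this position. Nothing available explains the size of this step.

As far as these compounds go, what a methoxy group, a chlorine atom or an amine at this aromatic carbon would give remains open. From the compounds shown here alone, it is also open whether the same exchange would read alike with another group on the amide nitrogen, such as the cyclohexylmethyl of compound 1.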